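This account rests on a few compounds, and the source may have more. Where it says the series, first, only, none or still open, it means among the compounds named here.

Measured so far in a functional assay on a cell-free system (plasma) with sterol O-acyltransferase, Soat (Rattus norvegicus) as the target; on this read-out lower numbers stand for an effect already at smaller amounts and higher numbers for an effect only at larger amounts of compound:
compound 1 `Cc1cc(C)c(NC(=O)N(Cc2ccc(-c3nnc(C)o3)cc2)C2CCCCCC2)c(C)c1`, recorded only as a limit, > 0.32 mg/kg.
compound 2 `Cc1cc(C)c(NC(=O)N(Cc2ccc(-c3cccs3)cc2)C2CCCCCC2)c(C)c1`, 0.28 mg/kg.
compound 3 `Cc1cc(C)c(NC(=O)N(Cc2ccc(-n3cccn3)cc2)C2CCCCCC2)c(C)c1`, recorded only as a limit, > 1 mg/kg.

Compound 3 thus stands at the higher of the two limits in this assay, (the limit of > 1 mg/kg in this assay, at which 1 of the 3 values shown sits). Compound 1 sits at the other limit, (the limit of > 0.32 mg/kg in this assay, at which 1 of the 3 values shown sits). Only compound 2 carries a number. The measured steps read: an at least 1.1-fold lower number from compound 1 to compound 2 (0.05 log units; that floor lies within the scatter); an at least 3.5-fold higher number from compound 2 to compound 3 (0.55 log units; beyond the scatter); a step that the two limits leave unreadable from compound 1 to compound 3.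

Compound 4 `Cc1cc(C)c(NC(=O)N(Cc2ccc(-c3ccn(C)n3)cc2)C2CCCCCC2)c(C)c1` differs from compound 3 in one place: 1-methyl-1H-pyrazol-3-yl in place of 1H-pyrazol-1-yl on an aromatic carbon. The pyrazole is retained; the name of the entering group marks a change of attachment and an added methyl. No measured step covers such a shift within one ring; the steps shown exchange one ring for another, and the step ending at compound 3 gives a floor but no size. The closest guidance is that compound 3 sits at a limit, and that the two other members of the series, compound 1 and compound 2, lie no higher than the other limit.

Compound 4 is therefore expected to remain close to where compound 3 stands, with the step of a number no higher from compound 3 to compound 4 (the limit leaves the size open) expected to be small or unreadable. The estimate for compound 4 is 1 mg/kg, with a range from 0.3 mg/kg to 3 mg/kg, and a substantial chance that only a limit is reported.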

Compound 4, dose for half-maximal effect: < 1 mg/kg
Compound 4: no number, only a limit; the forecaster's own chance of this, stated with the estimate: 55%; the middle value sits exactly at the limit.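

In this assay compound 4 is recorded only as a limit: the limit of < 1 mg/kg in this assay, at which 1 of the 4 values shown sits. Compound 3 is likewise recorded only as a limit, on the opposite side: the limit of > 1 mg/kg in this assay, at which 1 of the 4 values shown sits. The earlier steps shown here exchanged one ring for another, whereas this change keeps a five-membered aromatic ring with 2 hetero atoms on the same aromatic carbon, para to a large group, and still gives a number no higher from compound 3 to compound 4 (the limit leaves the size open), which shows that the presence of a pyrazole at this position does not alone fix where a compound falls on this read-out.

From the compounds shown here alone, the steps between compound 4 and compound 1 and compound 2 cannot be read, and neither can the size of the step from compound 3, so the standing of compound 4 against the thiophen-2-yl group of compound 2 remains unknown. Going by these compounds, the change of attachment and the added methyl also arrive together here, so the share of each stays open; a 1H-pyrazol-3-yl group without the methyl would separate them, and a carboxylic acid on the ring at this position would test a quite different kind of group.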